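This account rests on a few compounds, and the source may have more. Where it says the series, first, only, none or still open, it means among the compounds named here.

Compound 1 `O=C(NCCCCN1CCN(c2ccccc2)CC1)c1ccc(-c2ccsc2)cc1` gives 0.41 h in an ADME assay on microsomes from liver (Rattus norvegicus) for metabolic stability, read by LC-MS, using NADPH; a higher number here means that the compound lasts longer, a lower number that the compound disappears faster. Compound 2 `O=C(NCCCCN1CCN(c2cccc(Cl)c2)CC1)c1ccc(-c2ccsc2)cc1` gives 0.468 h in this assay, and compound 3 `O=C(NCCCCN1CCN(c2ccc(Cl)cc2Cl)CC1)c1ccc(-c2ccsc2)cc1` gives 0.3 h. Compound 3 holds the lowest of the three numbers, yet the steps of a 1.4-fold lower number from compound 1 to compound 3 (0.14 log units; within the scatter) and a 1.6-fold lower number from compound 2 to compound 3 (0.19 log units; within the scatter) both lie within the scatter, so the three compounds cannot be told apart on these numbers. Compound 4 `O=C(NCCCCN1CCN(c2ccccc2O)CC1)c1ccc(-c2ccsc2)cc1` differs from compound 3 by 2-hydroxyphenyl in place of 2,4-dichlorophenyl on an amine nitrogen in a ring. The measured steps that bear on this change, all of them on the same ring nitrogen, were a 1.1-fold higher number from compound 1 to compound 2 (0.06 log units; within the scatter), a 1.4-fold lower number from compound 1 to compound 3 (0.14 log units; within the scatter) and a 1.6-fold lower number from compound 2 to compound 3 (0.19 log units; within the scatter), and none left the scatter. On that basis compound 4 is expected to give a number close to that of compound 3. The expected step, a 1.3-fold higher number from compound 3 to compound 4 (0.12 log units; within the scatter), stays within the scatter. The estimate for compound 4 is 0.4 h, with a range from 0.2 h to 0.8 h.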

Compound 4, half-life: 0.157 h
Estimate against measurement, compound 4: 2.5-fold (0.41 log units) above, outside the stated range (below it).
By their numbers in this assay, from the lowest: compounds 4, 3, 1 and 2 (each within the scatter of the next, the first and the last beyond it).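

In this assay, among these compounds, hydroxy on the phenyl ring gives the only steps at this ring nitrogen that leave the scatter (a 2.6-fold lower number from compound 1 to compound 4 (0.42 log units; beyond the scatter)) and (a 3.0-fold lower number from compound 2 to compound 4 (0.47 log units; beyond the scatter)). Set against the 2,4-dichlorophenyl group, the same group stays within the scatter (a 1.9-fold lower number from compound 3 to compound 4 (0.28 log units; within the scatter)). Among the compounds shown here, the chloro compounds alone showed no effect of this position, whereas compound 4 shows that a change here can register, though it is the only compound to do so. Nothing at hand explains the shift. Going by these compounds, whether it depends on the free hydroxy remains open, and a methoxy or an amine in its place would bear on that.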